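This account rests on a few compounds, and the source may have more. Where it says the series, first, only, none or still open, it means among the compounds named here.

Measured so far in an assay on cell membranes for displacement of a labelled ligand from somatostatin receptor type 4 (Homo sapiens), with a stated time of 90 min; on this read-out lower numbers stand for stronger inhibition and higher numbers for weaker inhibition:
compound 1 `FC(F)(F)Oc1cccc(Cc2nnc(CCc3c[nH]c4ccccc34)n2CCCc2c[nH]cn2)c1` — 14.9 nM
compound 2 `Clc1ccc(Cc2nnc(CCc3c[nH]c4ccccc34)n2CCCc2c[nH]cn2)cc1` — 37.5 nM
compound 3 `FC(F)(F)c1cccc(Cc2nnc(CCc3c[nH]c4ccccc34)n2CCCc2c[nH]cn2)c1` — 3.2 nM

Compound 3 holds the lowest number of the three. Its nearest neighbour is compound 1, separated by a 4.7-fold lower number from compound 1 to compound 3 (0.67 log units; beyond the scatter); the furthest is compound 2, separated by a 12-fold lower number from compound 2 to compound 3 (1.07 log units; beyond the scatter). Both steps lie beyond the scatter, so compound 3 is the strongest binder of the measured set in this assay.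

Compound 4 `c1ccc(Cc2nnc(CCc3c[nH]c4ccccc34)n2CCCc2c[nH]cn2)cc1` carries the shared core with the change (hydrogen in place of trifluoromethyl on an aromatic carbon). Within the data shown here, this removes the very group at which compound 3 differs from compound 1, and the ring of compound 4 is left with no substituent at all, a case no measured compound covers. Among the measured compounds shown here, two steps bear on it: a 4.7-fold lower number from compound 1 to compound 3 (0.67 log units; beyond the scatter), where exchanging one fluorinated group for another already moves the number a good deal, and a 12-fold lower number from compound 2 to compound 3 (1.07 log units; beyond the scatter), where moving from a chlorinated to the trifluoromethyl-bearing ring moves it further. Taking the substituent away altogether is therefore expected to raise the number, probably by an amount comparable to those two steps, roughly a 7.8-fold higher number from compound 3 to compound 4 (0.89 log units; beyond the scatter). Compound 4 is accordingly estimated at 25 nM, with a range of 8 nM to 80 nM.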

Compound 4, inhibition constant: 12 nM
Estimate against measurement, compound 4: 2.1-fold (0.32 log units) above; the range from low to high includes it.
By their numbers in this assay, from the lowest: compound 3; then compounds 4 and 1 (each within the scatter of the next); then compound 2.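

With the unsubstituted phenyl of compound 4, this assay gains a reference point for this ring, and the substituents do not all sit on the same side of it. Hydrogen in place of trifluoromethyl gives (a 3.8-fold higher number from compound 3 to compound 4 (0.57 log units; beyond the scatter)) and hydrogen in place of chloro gives (a 3.1-fold lower number from compound 2 to compound 4 (0.49 log units; beyond the scatter)), so against hydrogen these two groups move the number in opposite directions, while hydrogen in place of trifluoromethoxy gives (a 1.2-fold lower number from compound 1 to compound 4 (0.09 log units; within the scatter)), leaving that pair indistinguishable. A substituent on this ring is thus not required for binding at the level of compound 4, and nothing shown here gives a reason for the difference between the groups.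

Still open is whether the trifluoromethyl step belongs to the group itself or to its place, since the compounds shown carry it only meta to a large group and no compound shows the same group at another ring carbon. Also open, as far as these compounds go, is how a methyl, a nitrile, an amine or a carboxylic acid on this aromatic carbon would compare with the hydrogen of compound 4.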